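From 4-nitrophenyl to 2,3-dichlorophenyl in compound 4

The compounds below may be only part of what the source reports. "The series", "measured", "known", "first", "only" and "open" are said of these compounds alone.

Measured in a functional assay on PC-3 cells (Homo sapiens) for antiproliferative activity, read by MTT assay, with a stated time of 72 h; on this read-out lower numbers stand for stronger inhibition and higher numbers for weaker inhibition:
- compound 1 `O=C(N/N=C/c1ccccc1)Nc1ccc(Oc2ccnc3[nH]ccc23)cc1`: 10200 nM
- compound 2 `O=C(N/N=C/c1ccc(Br)cc1)Nc1ccc(Oc2ccnc3[nH]ccc23)cc1`: "not active" (no number reported)
- compound 3 `O=C(N/N=C/c1ccc([N+](=O)[O-])cc1)Nc1ccc(Oc2ccnc3[nH]ccc23)cc1`: 28100 nM

Of the two numbers available in this assay, the higher belongs to compound 3 at 28100 nM. Compound 1 lies lower at 10200 nM, while compound 2 gave no number. The next structure, compound 4 `O=C(N/N=C/c1cccc(Cl)c1Cl)Nc1ccc(Oc2ccnc3[nH]ccc23)cc1`, differs from compound 3 as follows: 2,3-dichlorophenyl in place of 4-nitrophenyl on a carbon with a double bond to nitrogen. In words, this is 2,3-dichlorophenyl in place of 4-nitrophenyl on a carbon with a double bond to nitrogen.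

Within the data shown here, only one measured step bears on this change: a 2.8-fold higher number from compound 1 to compound 3 (0.44 log units; beyond the scatter), a modest rise on adding nitro in place of hydrogen. Compound 4 has no nitro, so a modest move toward a lower number is expected, though the evidence is thin. Among the measured compounds shown here, compound 2 offers no step, and a result without a number remains possible for compound 4.

The expected change is a 2.2-fold lower number from compound 3 to compound 4 (0.33 log units; beyond the scatter). For compound 4 the estimate is 13000 nM, with an expected range from 4500 nM to 38000 nM.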

Compound 4, half-maximal inhibitory concentration: "not active" (no number reported)
Nothing numeric was reported for compound 4; no gap can be computed for the estimate.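

In this assay, among these compounds, compound 4 is reported as "not active" without a number, so no step from compound 3 can be read, and no evidence bears on this result. The compounds shown leave open how compound 2 and compound 4, both without a number, stand relative to compound 1 and compound 3.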